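A few compounds are considered here, and "the series" means these few. Any claim that something is new, unique, unknown or untested is made for them only; others in the source may bear on it.

Compound 1 `CCCNC(=O)c1cc(Oc2ccc(NC(=O)c3nn(-c4ccc(C)cc4)c(=O)cc3C)cc2F)ccn1`: 34600 nM
Compound 2 `CNC(=O)c1cc(Oc2ccc(NC(=O)c3nn(-c4ccccc4Cl)c(=O)cc3C)cc2F)ccn1`: 136000 nM

In a functional assay on MCF7 cells (Homo sapiens) for antiproliferative activity, read by MTT assay, with a stated time of 72 h (a lower number here means a stronger inhibitor, a higher number a weaker inhibitor), compound 1 gives 34600 nM, the lower of the two numbers, and compound 2 gives 136000 nM, a gap beyond the scatter. Compound 3 `CCCNC(=O)c1cc(Oc2ccc(NC(=O)c3nn(-c4ccc(Br)cc4F)c(=O)cc3C)cc2F)ccn1` carries 4-bromo-2-fluorophenyl in place of 4-methylphenyl on an aromatic nitrogen. For the measured compounds named here, no pair of measured compounds differs in one place only, so nothing here shows directly what this exchange does. No step beyond the scatter is therefore expected in this assay, and the estimated step is a 1.2-fold lower number from compound 1 to compound 3 (0.06 log units; within the scatter). For compound 3 the estimate is 30000 nM, with an expected range from 10000 nM to 90000 nM.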

Compound 3, half-maximal inhibitory concentration: "not active" (no number reported)
No number was reported for compound 3; no gap can be computed for the estimate.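

For the compounds shown here, compound 3 is reported as "not active" in this assay with no number, so no step from compound 1 to compound 3 can be read. As far as these compounds go, how far 4-bromo-2-fluorophenyl in place of 4-methylphenyl shifts the number stays open. No measurement at hand accounts for this result.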